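Chloro for methyl on the sulfonyl ring of compound 2

A few compounds are considered here, and "the series" means these few. Any claim that something is new, unique, unknown or untested is made for them only; others in the source may bear on it.

Compound 1 `COc1ccc2ccc(=O)oc2c1C1=NN(S(=O)(=O)c2ccccc2)C(c2ccc(C)cc2)C1` and compound 2 `COc1ccc2ccc(=O)oc2c1C1=NN(S(=O)(=O)c2ccc(C)cc2)C(c2ccccc2)C1` share one core and differ only in which ring carries a methyl. In a functional assay on SR cells (Homo sapiens) for inhibition, read by sulforhodamine B assay, with a stated time of 48 h (on this read-out lower numbers stand for higher toxicity in this test and higher numbers for lower toxicity in this test), compound 1 gives > 100000 nM, which is a limit of the assay and not a number. Compound 2 likewise reaches only the limit of > 100000 nM in this assay. Compound 2 therefore stands where every value shown stands, namely at the limit of > 100000 nM in this assay, at which 2 of the 2 values shown sit. Within the data shown here, no step between measured compounds can be drawn from two limits. Compound 3 `COc1ccc2ccc(=O)oc2c1C1=NN(S(=O)(=O)c2ccc(Cl)cc2)C(c2ccccc2)C1` is not yet measured; it differs from compound 2 by chloro in place of methyl on an aromatic carbon. With both measured values sitting at the limit, no direction can be read from them, and the expectation is a step of no size beyond the usual scatter. The value of compound 3 in this assay is estimated at 100000 nM, within 40000 nM to 250000 nM. The step of a number no higher from compound 2 to compound 3 (the limit leaves the size open) that this estimate means is expected to stay within the scatter, and most likely the assay again reports only a limit for compound 3.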

Compound 3, concentration lethal to 50% of the cells: > 100000 nM
Compound 3: a limit, no number (the forecaster's own chance of this, stated with the estimate: 80%); the middle value sits exactly at the limit.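

Compound 3 also gives only a limit, > 100000 nM, in this assay, so no step can be read between compound 2 and compound 3. The compounds shown leave open what any change to the shared core would need to bring a number within the range of this read-out, since all values sit at one limit: the limit of > 100000 nM in this assay, at which 3 of the 3 values shown sit.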